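Trifluoromethyl in place of chloro on an aromatic carbon

A few compounds are considered here, and "the series" means these few. Any claim that something is new, unique, unknown or untested is made for them only; others in the source may bear on it.

Of the compounds shown here, three sharing one core have been measured in a functional assay on A-375 cells (Homo sapiens) for antiproliferative activity; a higher number here means that more compound is needed for the effect, a lower number that less compound is needed. Compound 1 `CC(=O)Nc1cn2cc(-c3cc(NC(=O)c4ccccc4)ccc3C)ccc2n1`, with a phenyl on the carbonyl carbon, gives 100 nM. Compound 2 `CC(=O)Nc1cn2cc(-c3cc(NC(=O)c4cc(C(F)(F)F)ccn4)ccc3C)ccc2n1`, with 4-(trifluoromethyl)pyridin-2-yl there, gives 280 nM. Compound 3 `CC(=O)Nc1cn2cc(-c3cc(NC(=O)c4cccc(Cl)c4)ccc3C)ccc2n1`, with 3-chlorophenyl there, gives 70 nM. That places it at the low end of the three numbers, level within the scatter with its nearest neighbour, a 1.4-fold lower number from compound 1 to compound 3 (0.15 log units; within the scatter), and clearly apart from the furthest, a 4.0-fold lower number from compound 2 to compound 3 (0.60 log units; beyond the scatter).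

Compound 4 `CC(=O)Nc1cn2cc(-c3cc(NC(=O)c4cccc(C(F)(F)F)c4)ccc3C)ccc2n1` makes one change to compound 3: trifluoromethyl in place of chloro on an aromatic carbon, meta to a large group (trifluoromethyl in place of chloro on an aromatic carbon). Within the data shown here, no measured pair isolates this exchange, so the evidence is indirect. Placing chloro on the phenyl left the number within the scatter, a 1.4-fold lower number from compound 1 to compound 3 (0.15 log units; within the scatter). Among the measured compounds shown here, the one measured compound bearing trifluoromethyl has a higher number, a 2.8-fold higher number from compound 1 to compound 2 (0.45 log units; beyond the scatter), but that step also exchanges the ring itself, so it says little about this change. No step beyond the scatter is therefore expected, and the estimate is a 1.1-fold higher number from compound 3 to compound 4 (0.06 log units; within the scatter). For compound 4 the expected value is 80 nM, with an estimated range of 30 nM to 200 nM.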

Compound 4, half-maximal effective concentration: 86 nM
Compound 4: middle estimate off by 1.1-fold (0.03 log units), on the low side, within the range that was stated.
By their numbers in this assay, from the lowest: compounds 3, 4 and 1 (each within the scatter of the next); then compound 2.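

In this assay the exchange of chloro for trifluoromethyl at this place on the phenyl, with one heavy atom leaving and four entering, stays within the scatter at a 1.2-fold higher number from compound 3 to compound 4 (0.09 log units; within the scatter) and compound 4 also stands level with the unsubstituted compound, at a 1.2-fold lower number from compound 1 to compound 4 (0.07 log units; within the scatter) on this same position. Trifluoromethyl is now seen on a phenyl as well as on the pyridine, and the gap of a 3.3-fold lower number from compound 2 to compound 4 (0.51 log units; beyond the scatter) lies beyond the scatter, so the higher number of compound 2 does not go with the presence of trifluoromethyl alone. No other measurement is available that explains any of these numbers.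

That step from compound 2 changes both the ring and the place of the trifluoromethyl, so the share of each in the gap remains unresolved. Chloro, trifluoromethyl and hydrogen all sit within the scatter of one another here, and it remains open whether the same holds for an amine, a hydroxyl or a carboxylic acid at this place on the phenyl.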